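From 3,4,5-Trimethoxyphenyl to 4-Methoxyphenyl in a Level Series

The source may report more compounds than this note shows. Statements on the series, on what has been measured and on what is new or still open speak of the compounds shown alone.

In a toxicity assay on CHO cells (Cricetulus griseus) for cytotoxicity, read by MTT assay (on this read-out higher numbers stand for weaker inhibition and lower numbers for stronger inhibition), compound 1 `O=C(N/N=C/c1ccccc1)c1cn(C2CC2)c2cc(N3CCNCC3)c(F)cc2c1=O` gives 25000 nM and compound 2 `O=C(N/N=C/c1ccc([N+](=O)[O-])cc1)c1cn(C2CC2)c2cc(N3CCNCC3)c(F)cc2c1=O` gives 25000 nM while compound 3 `COc1cc(/C=N/NC(=O)c2cn(C3CC3)c3cc(N4CCNCC4)c(F)cc3c2=O)cc(OC)c1OC` gives 25000 nM as its reading, which places compound 3 level with both of the others. Compound 4 `COc1ccc(/C=N/NC(=O)c2cn(C3CC3)c3cc(N4CCNCC4)c(F)cc3c2=O)cc1` differs from compound 3 at one place. The difference is 4-methoxyphenyl in place of 3,4,5-trimethoxyphenyl on a carbon with a double bond to nitrogen. It consists of 4-methoxyphenyl in place of 3,4,5-trimethoxyphenyl on a carbon with a double bond to nitrogen. Among the measured compounds shown here, three measured steps bear on it. Here 3,4,5-trimethoxyphenyl in place of phenyl gives no change at the digits printed from compound 1 to compound 3 (within the scatter) at that carbon, nitro in place of hydrogen on an aromatic carbon gives no change at the digits printed from compound 1 to compound 2 (within the scatter) in the same group, and 3,4,5-trimethoxyphenyl in place of 4-nitrophenyl gives no change at the digits printed from compound 2 to compound 3 (within the scatter) at that carbon again. For the measured compounds named here, none of the three goes beyond the scatter, and no measured compound yet carries 4-methoxyphenyl, so no step beyond the scatter is expected in this assay for this exchange. The expected change is no change at the digits printed from compound 3 to compound 4 (within the scatter) on this estimate. Compound 4 is expected at 25000 nM with an estimated range from 14000 nM to 40000 nM on this read-out.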

Compound 4, half-maximal inhibitory concentration: 25000 nM
Compound 4: the middle estimate sits on the measured number at the digits printed; the measured number falls inside the stated range.
By their numbers in this assay, from the lowest: compounds 1, 2, 3 and 4 (each within the scatter of the next).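

In this assay, among the compounds shown here, the first methoxy-bearing group with a single methoxy at this carbon, 4-methoxyphenyl in place of 3,4,5-trimethoxyphenyl, gives no change at the digits printed from compound 3 to compound 4 (within the scatter). Methoxy in place of nitro on an aromatic carbon gives no change at the digits printed from compound 2 to compound 4 (within the scatter), and methoxy in place of hydrogen gives no change at the digits printed from compound 1 to compound 4 (within the scatter), so phenyl, 4-nitrophenyl, 3,4,5-trimethoxyphenyl and 4-methoxyphenyl cannot be told apart on this read-out. No measurement at hand offers an explanation for this sameness.

From the compounds shown here alone, whether an amine or a carboxylic acid on the phenyl group, or a longer chain in place of that group, would move the reading remains open. All four compounds also share the same core, so what a change there would do in this assay is open too.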